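This account rests on a few compounds, and the source may have more. Where it says the series, first, only, none or still open, it means among the compounds named here.

Three close relatives of one shared core have been measured in a functional assay for agonist activity at Alpha-1A adrenergic receptor (Homo sapiens); on this read-out higher numbers stand for an effect only at larger amounts of compound and lower numbers for an effect already at smaller amounts. Compound 1 `CS(=O)(=O)c1ccc(Cl)cc1NCC1=NCCN1` gives 2.82 nM, compound 2 `Cc1ccc(S(C)(=O)=O)c(NCC2=NCCN2)c1` gives 1.95 nM, and compound 3 `COc1ccc(S(C)(=O)=O)c(NCC2=NCCN2)c1` gives 14.1 nM, the highest of the three numbers. The steps of a 5.0-fold higher number from compound 1 to compound 3 (0.70 log units; beyond the scatter) and a 7.2-fold higher number from compound 2 to compound 3 (0.86 log units; beyond the scatter) both lie beyond the scatter, while a 1.4-fold lower number from compound 1 to compound 2 (0.16 log units; within the scatter) does not. Compound 4 `CS(=O)(=O)c1ccc(C(F)(F)F)cc1NCC1=NCCN1` differs from compound 3 by a single change: trifluoromethyl in place of methoxy on an aromatic carbon. The two steps ending at compound 3 bear on this change, since each time a group other than methoxy sat on that aromatic carbon the number was lower. A drop is therefore expected, a 4.7-fold lower number from compound 3 to compound 4 (0.67 log units; beyond the scatter), back toward the numbers of compound 1 and compound 2. Compound 4 is estimated at 3 nM, with a range from 1 nM to 10 nM.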

Compound 4, half-maximal effective concentration: 1100 nM
Beside the measured number, compound 4's estimate is 370-fold (2.56 log units) below it, outside the stated range (above it).
By their numbers in this assay, from the lowest: compounds 2 and 1 (each within the scatter of the next); then compound 3; then compound 4.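

Until now, the groups on this aromatic carbon, para to a methylsulfonyl group, had shifted the number only modestly or within the scatter, yet trifluoromethyl gives a 78-fold higher number from compound 3 to compound 4 (1.89 log units; beyond the scatter) and a 390-fold higher number from compound 1 to compound 4 (2.59 log units; beyond the scatter) and also a 560-fold higher number from compound 2 to compound 4 (2.75 log units; beyond the scatter) in the same series. The position therefore accepts methyl, chloro and methoxy but not every group, and the loss is large whichever of those three trifluoromethyl replaces. Going by these compounds, whether an amine, a nitrile or an ethyl group here would keep the lower numbers or fall toward compound 4 stays open. Nothing available explains why trifluoromethyl parts so sharply from the other three groups.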